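This account rests on a few compounds, and the source may have more. Where it says the series, first, only, none or still open, it means among the compounds named here.

Measured compounds:
compound 1 `CN(c1ncccc1CNc1nc(Nc2ccc3c(c2)CC(=O)N3)nc2[nH]cc(F)c12)S(C)(=O)=O` — 73200 nM in a functional assay on SMMC-7721 cells (Homo sapiens) for inhibition, read by MTT assay, with a stated time of 48 h; on this read-out higher numbers stand for weaker inhibition and lower numbers for stronger inhibition
compound 2 `COc1cccc(Nc2nc(NCc3cccnc3N(C)S(C)(=O)=O)c3c(F)c[nH]c3n2)c1C` — in this assay compound 2 reaches only the limit of > 100000 nM

Compound 2 stands at the limit of this assay: its value is not a number but the boundary of what the assay reports, as the line the limit of > 100000 nM in this assay, at which 1 of the 2 values shown sits, records. For the measured compounds named here, the only measured step, an at least 1.3-fold higher number from compound 1 to compound 2 (0.13 log units; that floor lies within the scatter), exchanges the group on the nitrogen on the aromatic ring and lands at that floor, so it cannot be sized beyond the scatter.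

Compound 3 `CC(=O)Nc1cccc(Nc2nc(NCc3cccnc3N(C)S(C)(=O)=O)c3c(F)c[nH]c3n2)c1` differs from compound 2 by 3-acetamidophenyl in place of 3-methoxy-2-methylphenyl on a nitrogen on an aromatic ring. Going by the values given here, this change sits at the same nitrogen that the measured step altered, but no measured pair shares the acetamido group, so the step from compound 1 to compound 2 bears on it only in kind, not in size. Compound 1, whose group on that nitrogen carries a carbonyl, gives 73200 nM; compound 3 likewise carries a carbonyl in its acetamido group. Compound 3 is therefore expected to sit near that weak end, an expected step of an at least 1.2-fold lower number from compound 2 to compound 3 (0.09 log units; that floor lies within the scatter) from the limit of compound 2. The estimate for compound 3 in this assay is 80000 nM, within a range of 30000 nM to 200000 nM.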

Compound 3, half-maximal inhibitory concentration: 16000 nM
Compound 3: middle estimate off by 5.0-fold (0.70 log units), on the high side; the measured number lies below the stated range.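

The position on the nitrogen on the aromatic ring now yields a step that can be sized beyond the scatter: 3-acetamidophenyl in place of 3-methoxy-2-methylphenyl gives an at least 6.2-fold lower number from compound 2 to compound 3 (0.79 log units; beyond the scatter). That size is only a floor, since compound 2 gives no number in this assay: the limit of > 100000 nM in this assay, at which 1 of the 3 values shown sits. Two groups with the same heavy atoms also read apart, one with the five-membered non-aromatic ring and one without it, in a 4.6-fold lower number from compound 1 to compound 3 (0.66 log units; beyond the scatter), so in these compounds the presence of a carbonyl in the group does not by itself settle the read-out.

The compounds shown do not separate the amide hydrogen, the carbonyl and the place of the acetamido group on the phenyl ring, so which of these goes with the lower number stays open. On these data alone, how a phenyl ring carrying an amine or a carboxylic acid would read on this nitrogen also remains unknown, as does whether the step from 3-methoxy-2-methylphenyl to 3-acetamidophenyl keeps its size with other groups elsewhere on the shared core.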